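Hydroxy to Methoxy: Expected Shift in Cellular Inhibition

The source may hold more compounds than are shown below. What is called first, only, known or untested is meant among the compounds shown, and "the series" means these compounds.

Values in a functional assay on ACHN cells (Homo sapiens) for inhibition, read by sulforhodamine B assay, with a stated time of 48 h, tested at 10 uM; on this read-out lower numbers stand for a stronger effect and higher numbers for a weaker effect at the one concentration tested:
Compound 1 `COc1cc(Cl)cc(-c2nn(-c3cccc(NC(=O)c4ccc(Cl)c(Cl)c4)c3)cc2-c2ccncc2)c1`: 63.9%
Compound 2 `O=C(Nc1cccc(-n2cc(-c3ccncc3)c(-c3cc(O)cc(Cl)c3)n2)c1)Nc1ccc(Cl)c(C(F)(F)F)c1`: 21.3%
Compound 3 `O=C(Nc1cccc(-n2cc(-c3ccncc3)c(-c3cc(O)cc(Cl)c3)n2)c1)Nc1ccc(Cl)c(Cl)c1`: 6.85%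

Compound 2 stands second highest of the three numbers. Compound 3 lies below it by a number 14.5 percentage points lower from compound 2 to compound 3 (beyond the scatter), a step beyond the scatter, while compound 1 sits well above it; compound 1 differs from compound 2 in two places, so its value gives no single-change reading. Compound 4 `COc1cc(Cl)cc(-c2nn(-c3cccc(NC(=O)Nc4ccc(Cl)c(C(F)(F)F)c4)c3)cc2-c2ccncc2)c1` differs from compound 2 by methyl in place of hydrogen on an oxygen on an aromatic ring. Among the compounds with values here, no measured step touches this oxygen, so direct guidance is absent; the high value of compound 1, which also carries methoxy, hints only loosely at a weaker effect. Compound 4 is therefore expected to show an upward step of a number 13.7 percentage points higher from compound 2 to compound 4 (beyond the scatter) in this assay. The value of compound 4 is estimated at 35%, within 15% to 60%.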

Compound 4, a percentage reported as activity, at one concentration (the size of the read-out at that concentration, not a potency): 8.78%
Compound 4: the middle estimate sits 26.2 percentage points above what was measured; measured number below the stated range.
By their numbers in this assay, from the lowest: compounds 3 and 4 (each within the scatter of the next); then compound 2; then compound 1.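

In this assay, methyl in place of hydrogen on this oxygen does not weaken the effect: hydroxy to methoxy gives a number 12.5 percentage points lower from compound 2 to compound 4 (beyond the scatter), so the free hydroxy is not needed here. With methoxy kept, a number 55.1 percentage points lower from compound 1 to compound 4 (beyond the scatter), which ties the high number of compound 1 to the change on the carbonyl carbon rather than to methoxy. Nothing available explains either step.

As far as these compounds go, whether an amine or an ethoxy group on this aromatic carbon would keep the effect remains open. So does whether methoxy behaves alike in compound 3, which carries 3,4-dichlorophenyl.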